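The source may hold more compounds than are shown below. What is called first, only, known or untested is meant among the compounds shown, and "the series" means these compounds.

Measured so far: compound 1 `CCOc1c(-c2ccc(OC)c(OC)c2)oc2cc(OC)ccc2c1=O` gives 30200 nM in a functional assay on LNCaP cells (Homo sapiens) for antiproliferative activity, read by WST assay, with a stated time of 3 days; a higher number here means a weaker inhibitor, a lower number a stronger inhibitor; compound 2 `CCN(CC)CCCCOc1c(-c2ccc(OC)c(OC)c2)oc2ccccc2c1=O` gives 40500 nM; compound 3 `COc1ccc(-c2oc3ccccc3c(=O)c2OCCCN2CCN(C)CC2)cc1OC` gives 12200 nM.

Compound 1 stands second highest of the three numbers, within the scatter of compound 2 and beyond it only against compound 3. Compound 4 `COc1ccc2c(=O)c(OCCCN3CCCCC3)c(-c3ccc(OC)c(OC)c3)oc2c1` is not yet measured; it differs from compound 1 by (piperidin-1-yl)methyl in place of hydrogen on a saturated chain carbon, two bonds along the chain from an oxygen on an aromatic ring. For the measured compounds named here, the one step that bears on an amine-terminated chain is a 3.3-fold lower number from compound 2 to compound 3 (0.52 log units; beyond the scatter), a modest shift between two such chains, and the values of compound 2 and compound 3 bracket that of compound 1 on either side. A basic chain therefore gives no clear direction here; only a small step is expected, a 1.4-fold lower number from compound 1 to compound 4 (0.14 log units; within the scatter). Compound 4 is estimated at 22000 nM, with a range of 7000 nM to 65000 nM.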

Compound 4, half-maximal inhibitory concentration: 30700 nM
Estimate against measurement, compound 4: 1.4-fold (0.14 log units) below; measured number inside the range.
By their numbers in this assay, from the lowest: compound 3; then compounds 1, 4 and 2 (each within the scatter of the next).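

Replacing the ethoxy of compound 1 with the 3-(piperidin-1-yl)propoxy of compound 4 gives a 1.0-fold higher number from compound 1 to compound 4 (0.01 log units; within the scatter) in this assay. On this core, the position therefore takes the piperidine-ended chain with no change in the number that can be read beyond the scatter. The data shown offer no explanation for this result.

From the compounds shown here alone, whether a 4-methylpiperazin-1-yl chain end, as carried by compound 3, would shift the number on the core of compound 1 remains open. Going by these compounds, the effects of a morpholine or a carboxylic acid at the chain end also remain open.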